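Formyl in Place of Bromo: Expecting the Next Step

A few compounds are considered here, and "the series" means these few. Any claim that something is new, unique, unknown or untested is made for them only; others in the source may bear on it.

Compound 1 `CC(Oc1ccccc1Br)C1=NCCN1` in a functional assay on CHO cells for agonist activity at Alpha-2B adrenergic receptor (Homo sapiens) (a lower number here means that less compound is needed, a higher number that more compound is needed for the effect), gives 316 nM.
Compound 2 `C=C(C)c1ccccc1OC(C)C1=NCCN1` gives 1580 nM.
Compound 3 `CC(C)Oc1ccccc1OC(C)C1=NCCN1` gives 1740 nM.

Compound 1 stands lowest of the three: a 5.0-fold higher number from compound 1 to compound 2 (0.70 log units; beyond the scatter) and a 5.5-fold higher number from compound 1 to compound 3 (0.74 log units; beyond the scatter) show that both exchanges of its bromo raised the number by a modest, clearly resolved amount, while compound 2 and compound 3 sit within the scatter of each other. Compound 4 `CC(Oc1ccccc1C=O)C1=NCCN1` differs from compound 1 by formyl in place of bromo on an aromatic carbon. Neither measured step involves a formyl, so the closest guide is simply that each replacement of the bromo so far gave a higher number. The expected step is therefore a modest rise, a 3.2-fold higher number from compound 1 to compound 4 (0.50 log units; beyond the scatter). Compound 4 is estimated at 1000 nM, with a range from 300 nM to 3200 nM.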

Compound 4, half-maximal effective concentration: 316 nM
Compound 4: middle estimate off by 3.2-fold (0.50 log units), on the high side; measured number inside the range.
By their numbers in this assay, from the lowest: compounds 1 and 4 (each within the scatter of the next); then compounds 2 and 3 (each within the scatter of the next).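

Formyl in place of bromo gives no change at the digits printed from compound 1 to compound 4 (within the scatter) and thus shows that bromo is not the only group at this aromatic carbon that holds the number low. Formyl also stands apart from the other two replacements, with a 5.5-fold lower number from compound 3 to compound 4 (0.74 log units; beyond the scatter) on going from isopropoxy and a 5.0-fold lower number from compound 2 to compound 4 (0.70 log units; beyond the scatter) on going from 1-methylethenyl, so replacing bromo does not always raise the number. No evidence is available to explain these differences. Going by these compounds, whether other groups at this position, such as a nitrile or an amine, would also keep the number this low remains open.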